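This account rests on a few compounds, and the source may have more. Where it says the series, first, only, none or still open, it means among the compounds named here.

Within the data shown here, compound 3 `Clc1cc(Cl)c(Cn2cc(CCCOc3cccc4cccnc34)nn2)c(Cl)c1` sits second highest of the three numbers so far: in a functional assay on 786-0 cells (Homo sapiens) for inhibition, read by sulforhodamine B assay, with a stated time of 48 h (on this read-out lower numbers stand for stronger inhibition of growth and higher numbers for weaker inhibition of growth), compound 3 gives 5.6 ug/mL, with compound 1 `Clc1ccc(Cn2cc(CCCOc3cccc4cccnc34)nn2)cc1` nearest at 2.8 ug/mL and compound 2 `Brc1ccc(Cn2cc(CCCOc3cccc4cccnc34)nn2)cc1` furthest at 25.9 ug/mL. Compound 4 `c1ccc(Cn2cc(CCCOc3cccc4cccnc34)nn2)cc1` differs from compound 3 by phenyl in place of 2,4,6-trichlorophenyl on a saturated chain carbon bound to an aromatic nitrogen. Among the measured compounds shown here, two measured steps touch the same place: a 2.0-fold higher number from compound 1 to compound 3 (0.30 log units; within the scatter) and a 4.6-fold lower number from compound 2 to compound 3 (0.67 log units; beyond the scatter), while a 9.3-fold higher number from compound 1 to compound 2 (0.97 log units; beyond the scatter) shows that a single halogen exchange can move the number more than the exchange of 4-chlorophenyl for 2,4,6-trichlorophenyl does. Taking the change all the way to phenyl has no direct precedent; the expected step of a 1.4-fold higher number from compound 3 to compound 4 (0.15 log units; within the scatter) is therefore a small one, direction uncertain. Compound 4 is expected at 8 ug/mL, with an estimated range of 2 ug/mL to 30 ug/mL.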

Compound 4, concentration for 50% growth inhibition: 25 ug/mL
Beside the measured number, compound 4's estimate is 3.1-fold (0.49 log units) below it; measured number inside the range.
By their numbers in this assay, from the lowest: compounds 1 and 3 (each within the scatter of the next); then compounds 4 and 2 (each within the scatter of the next).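

Chlorine on the aromatic ring counts here: hydrogen in place of chloro gives the step (an 8.9-fold higher number from compound 1 to compound 4 (0.95 log units; beyond the scatter)), and phenyl in place of 2,4,6-trichlorophenyl gives a similar one (a 4.5-fold higher number from compound 3 to compound 4 (0.65 log units; beyond the scatter)). Halogen as such does not lower the number, since compound 2 goes against that reading: hydrogen in place of bromo gives only (a 1.0-fold lower number from compound 2 to compound 4 (0.02 log units; within the scatter)). No evidence bears on why chloro and bromo part here.

Open, from the compounds shown here alone, is whether fluoro or methoxy in place of chloro keeps the lower number of compound 1. Also open, going by these compounds, is how a longer chain in the shared core would read.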